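Replacing a Cyanophenyl with Pyridinyl on the Benzylamine Arm

The source may hold more compounds than are shown below. What is called first, only, known or untested is meant among the compounds shown, and "the series" means these compounds.

Measured so far:
compound 1 `Nc1nc(N)c(-c2ccc(NCc3cc(F)c(S(=O)(=O)C(F)(F)F)c(F)c3)cc2)c(COCc2ccccc2)n1` 1 nM
compound 2 `CC(=O)c1ccc(CNc2ccc(-c3c(N)nc(N)nc3COCc3ccccc3)cc2)cc1` 1.2 nM
compound 3 `N#Cc1ccc(CNc2ccc(-c3c(N)nc(N)nc3COCc3ccccc3)cc2)cc1` 2.8 nM

In an in vitro assay on CHOK cells for displacement of a labelled ligand from growth hormone secretagogue receptor type 1 (Homo sapiens) (a lower number here means a stronger inhibitor, a higher number a weaker inhibitor), compound 3 gives the highest of the three numbers, with compound 2 nearest and compound 1 furthest away. The only single-point step shown is a 2.3-fold higher number from compound 2 to compound 3 (0.37 log units; beyond the scatter), a modest change. Compound 4 `Nc1nc(N)c(-c2ccc(NCc3ccncc3)cc2)c(COCc2ccccc2)n1` differs from compound 3 by pyridin-4-yl in place of 4-cyanophenyl on a saturated chain carbon bound to a nitrogen on an aromatic ring. Within the data shown here, no measured step touches this change; the step from compound 2 to compound 3 only shows that the group on that arm shifts the number modestly. A step of similar size, towards a higher number, is therefore the expectation, stated as a 1.8-fold higher number from compound 3 to compound 4 (0.25 log units; within the scatter). Compound 4 is thus estimated at 5 nM, with a range from 1.5 nM to 20 nM.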

Compound 4, half-maximal inhibitory concentration: 21 nM
Beside the measured number, compound 4's estimate is 4.2-fold (0.62 log units) below it; the whole stated range lies below it.
By their numbers in this assay, from the lowest: compounds 1 and 2 (each within the scatter of the next); then compound 3; then compound 4.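

In this assay, this arm proves more sensitive than the swap of acetyl for cyano suggested: pyridin-4-yl in place of 4-cyanophenyl gives a 7.5-fold higher number from compound 3 to compound 4 (0.88 log units; beyond the scatter), and pyridin-4-yl in place of 4-acetylphenyl gives an 18-fold higher number from compound 2 to compound 4 (1.24 log units; beyond the scatter). Pyridin-4-yl is therefore not interchangeable here with either substituted phenyl ring. Nothing available accounts for the rise.

From the compounds shown here alone, it remains open whether the rise goes with the ring nitrogen or with the loss of the cyano or acetyl group. An unsubstituted phenyl and a cyano-bearing pyridine on this arm would separate the two.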